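This account rests on a few compounds, and the source may have more. Where it says the series, first, only, none or still open, it means among the compounds named here.

Measured compounds:
- compound 1, `CC(C)c1c(C(=O)NCC2CCCCC2)nn(-c2ccc(F)cc2)c1OC[C@@H](O)C[C@@H](O)CC(=O)O`: "not determined" (no result reported) in a functional assay on L6 cells (Rattus norvegicus) for inhibition; on this read-out lower numbers stand for stronger inhibition and higher numbers for weaker inhibition
- compound 2, `CC(C)c1c(C(=O)N2CCCCC2)nn(-c2ccc(F)cc2)c1OC[C@@H](O)C[C@@H](O)CC(=O)O`: 32200 nM
- compound 3, `CC(C)c1c(C(=O)NCc2cccc(Cl)c2)nn(-c2ccc(F)cc2)c1OC[C@@H](O)C[C@@H](O)CC(=O)O`: "not determined" (no result reported)

For the measured compounds named here, compound 1 has no number of its own in this assay, so its standing cannot be placed; the only number among the three is that of compound 2, and in this assay compound 2 gives 32200 nM, which is weak inhibition. Compound 3, like compound 1, has no result.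

Compound 4, `CC(C)c1c(C(=O)N(C)Cc2ccc(F)c(F)c2)nn(-c2ccc(F)cc2)c1OC[C@@H](O)C[C@@H](O)CC(=O)O`, is not yet measured. It differs from compound 1 in one place: (3,4-difluorobenzyl)(methyl)amino in place of (cyclohexylmethyl)amino on a carbonyl carbon. With no number for compound 1 and no measured step between any two of these compounds, neither the size nor the direction of the step from compound 1 to compound 4 can be taken from the data; the expectation rests only on the weak number of compound 2, whose amide piece is a different one.

Compound 4 is therefore estimated to give about 20000 nM in this assay, with an expected range from 3000 nM to 100000 nM.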

Compound 4, half-maximal inhibitory concentration: 4570 nM
The estimate for compound 4 lay 4.4-fold (0.64 log units) above the measured number; the measured number falls inside the stated range.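

In this assay, for the compounds shown here, a 7.0-fold lower number from compound 2 to compound 4 (0.85 log units; beyond the scatter) is the first measured step, and it shows that the group on this carbonyl carbon can change the inhibition beyond the usual scatter when (3,4-difluorobenzyl)(methyl)amino takes the place of piperidin-1-yl. The step from compound 1 to compound 4 cannot be read, since compound 1 has no number, so this single step is all the data offer about the position. Nothing measured here explains why the number falls.

The change replaces the whole amide piece at once, so the compounds shown do not separate the part played by the aromatic ring, the two fluorines or the methyl on the nitrogen. As far as these compounds go, how a plain benzyl(methyl)amino group without fluorine, or a morpholin-4-yl group, would read at this position stays open.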